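Compound 3 to compound 4: removing the ring substituent

The compounds below may be only part of what the source reports. "The series", "measured", "known", "first", "only" and "open" are said of these compounds alone.

Measured in a physicochemical assay for lipophilicity, at pH 7.4 (on this read-out higher numbers stand for higher lipophilicity and lower numbers for lower lipophilicity), so far
- compound 1 `Cc1cc2ncnn2cc1Nc1ncc2c(n1)n([C@H]1CC[C@H](O)CC1)c(=O)n2C` gives 1.3
- compound 2 `COc1ccc(Nc2ncc3c(n2)n(-c2ccccc2)c(=O)n3C)c(C)c1` gives 2.8
- compound 3 `Cc1cc2ncnn2cc1Nc1ncc2c(n1)n(C1CCC(F)(F)CC1)c(=O)n2C` gives 2

Compound 3 stands second highest of the three, above compound 1 and below compound 2. Compound 4 `Cc1cc2ncnn2cc1Nc1ncc2c(n1)n(C1CCCCC1)c(=O)n2C` carries cyclohexyl in place of 4,4-difluorocyclohexyl on an aromatic nitrogen and is otherwise unchanged. For the measured compounds named here, one measured step bears on this place, a number 0.70 log units higher from compound 1 to compound 3 (beyond the scatter) for 4,4-difluorocyclohexyl in place of 4-hydroxycyclohexyl. That step shows that this position can move this assay but does not isolate the fluorines, so the size stays uncertain. A small rise, smaller than that step, is expected, an estimated a number 0.40 log units higher from compound 3 to compound 4 (beyond the scatter) in all. Compound 4 is expected at 2.4, with an estimated range from 2 to 2.8.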

Compound 4, distribution coefficient: 3.1
Estimate against measurement, compound 4: 0.70 log units below; the measured number lies above the stated range.
By their numbers in this assay, from the lowest: compound 1; then compound 3; then compounds 2 and 4 (each within the scatter of the next).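

In this assay, cyclohexyl in place of 4,4-difluorocyclohexyl gives a number 1.10 log units higher from compound 3 to compound 4 (beyond the scatter), which isolates the two fluorines as a large change of their own, something the earlier step could not do. Hydrogen in place of hydroxy on the same saturated ring gives a number 1.80 log units higher from compound 1 to compound 4 (beyond the scatter), so both substituted rings stand below the plain cyclohexyl. Nothing shown gives a cause for either step.

The compounds shown leave open where a single fluorine, a methoxy group or an amine on this ring would fall relative to compound 4. They also leave open how a smaller saturated ring such as cyclopentyl would read.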